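The source may hold more compounds than are shown below. What is called first, only, known or untested is meant among the compounds shown, and "the series" means these compounds.

Working notes on the series. Three compounds sharing the core of compound 1 (`Cc1nc(NC(=O)C(C)(C)CC(F)(F)F)sc1-c1ccc(N)nc1`) have been run through a physicochemical assay for solubility, at pH 6.8 (on this read-out lower numbers stand for lower solubility and higher numbers for higher solubility), and compound 1 gives 13 ug/mL there. Compound 2 (`Cc1nc(NC(=O)CN(Cc2ccccc2)C(=O)c2ccncc2)sc1-c1ccc(N)nc1`) gives 125 ug/mL in this assay, and compound 3 (`Cc1nc(NC(=O)CN2C(=O)OC[C@H]2C(C)C)sc1-c1ccc(N)cc1`) gives 2.5 ug/mL. Compound 1 therefore stands second highest of the three: the gap down to compound 3 is beyond the usual scatter, and so is the gap up to compound 2. No two of the measured compounds differ in only one place, so no single structural step can be read directly from these numbers; the values only show that the amide substituent on this core moves solubility over a wide span.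

Compound 4 (`CO[C@H]1CC[C@@H](C(=O)Nc2nc(C)c(-c3ccc(N)nc3)s2)CC1`) is the next compound, not yet measured in this assay. Relative to compound 1 the change is 4-methoxycyclohexyl in place of 3,3,3-trifluoro-1,1-dimethylpropyl on a carbonyl carbon. Starting from compound 1 at 13 ug/mL, the step from compound 1 to compound 4 is expected to be upward and modest, a 2.3-fold higher number from compound 1 to compound 4 (0.36 log units; beyond the scatter), with a fair chance that it stays within the scatter. Compound 4 is accordingly estimated at 30 ug/mL in this assay, within a range of 8 ug/mL to 110 ug/mL.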

Compound 4, solubility: 14 ug/mL
Estimate against measurement, compound 4: 2.1-fold (0.33 log units) above; low and high end bracket the measured number.
By their numbers in this assay, from the lowest: compound 3; then compounds 1 and 4 (each within the scatter of the next); then compound 2.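

In this assay, within the data shown here, the first single-place comparison at this position gives a 1.1-fold higher number from compound 1 to compound 4 (0.03 log units; within the scatter), so 3,3,3-trifluoro-1,1-dimethylpropyl and 4-methoxycyclohexyl on a carbonyl carbon cannot be told apart on this read-out. The exchange is not a small one in structure: an open group with no ring, fluorine and no hydrogen-bond acceptor gives way to a six-membered non-aromatic ring with oxygen, one hydrogen-bond acceptor and two defined stereocentres, at the same heavy-atom count, and still the two numbers stay within the scatter of each other. Nothing available bears on why these two groups read alike.

Still open, on these data alone, is whether a different type of group at this place, such as an amine or a carboxylic acid, would give a step beyond the scatter, and whether plain cyclohexyl would read the same as 4-methoxycyclohexyl. The wide span set by compound 2 and compound 3 also remains unassigned, as neither has a single-place step to compound 1 or compound 4.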